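Swapping methoxy for fluoro on a chromane core

The source may report more compounds than this note shows. Statements on the series, on what has been measured and on what is new or still open speak of the compounds shown alone.

Four compounds share a fused two-ring core carrying a chain that ends in a cyclic amidine. Compound 1 `c1ccc2c(c1)CCC(CNCCCCCNC1=NCCCN1)O2` is the unsubstituted parent with the longer chain, and in an assay on isolated protein (Bos taurus) with 5-hydroxytryptamine receptor 1D (Homo sapiens) as the target (a higher number here means a weaker inhibitor, a lower number a stronger inhibitor), compound 1 gives 10 nM. Compound 3 `COc1cccc2c1OC(CNCCCNC1=NCCCN1)CC2` carries a methoxy group at a different position of the aromatic ring, and in this assay compound 3 gives 0.794 nM. Compound 2 `COc1ccc2c(c1)CCC(CNCCCNC1=NCCCN1)O2` also carries a methoxy group, but on another aromatic carbon. For compound 2 the result in this assay is only a limit, > 1000 nM, which is the upper boundary of what the method reports the limit of > 1000 nM in this assay, at which 1 of the 3 values shown sits, rather than a measured number; among the three results shown, compound 2 is the only one left at that boundary.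

Compound 4 `Fc1ccc2c(c1)CCC(CNCCCNC1=NCCCN1)O2` is the next compound, not yet measured in this assay. It differs from compound 2 in one respect: fluoro in place of methoxy on an aromatic carbon. Going by the values given here, no step between two measured compounds isolates this exchange, so the direction has to be an expectation rather than a reading from the data. Among the compounds with values here, the expected step from compound 2 to compound 4 is an at least 6.6-fold lower number from compound 2 to compound 4 (0.82 log units; beyond the scatter), a gain in potency, because the only figure that anchors compound 2 is the limit (the limit of > 1000 nM in this assay, at which 1 of the 3 values shown sits). Compound 4 is accordingly expected to give about 150 nM in this assay, with a plausible range from 15 nM to 1500 nM.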

Compound 4, half-maximal inhibitory concentration: 7.94 nM
For compound 4 the middle estimate is 19-fold (1.28 log units) above the measured one; the whole stated range lies above it.
By their numbers in this assay, from the lowest: compound 3; then compounds 4 and 1 (each within the scatter of the next). At a limit, above all of these: compound 2.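

Exchanging methoxy for fluoro on this aromatic carbon, with nothing else altered, gives an at least 120-fold lower number from compound 2 to compound 4 (2.10 log units; beyond the scatter) in this assay. The very weak result of compound 2 therefore goes with the methoxy group on this carbon, not with the chain or the rest of the core, both of which compound 4 keeps unchanged. The true size of the step cannot be read and may be larger, because compound 2 has only a limit and not a measured number: the limit of > 1000 nM in this assay, at which 1 of the 4 values shown sits.

As far as these compounds go, what remains open is whether the gain comes from removing methoxy or from adding fluoro, a question that a compound with this same chain and a plain hydrogen on this carbon would help to answer. From the compounds shown here alone, it is also open how other small groups on this carbon, such as chloro, methyl or hydroxy, would compare with fluoro, and whether fluoro would behave the same way on the aromatic carbon that carries methoxy in compound 3.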